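The source may hold more compounds than are shown below. What is called first, only, known or untested is meant among the compounds shown, and "the series" means these compounds.

Measured so far in an assay for inhibition of Polyunsaturated fatty acid lipoxygenase ALOX12 (Homo sapiens), read by spectrophotometry; on this read-out higher numbers stand for weaker inhibition and lower numbers for stronger inhibition:
Compound 1 `CCC(=O)NC(c1cccs1)c1cc(Br)c2cccnc2c1O` gives 14000 nM.
Compound 2 `CCC(=O)NC(c1ccco1)c1cc(Cl)c2cccnc2c1O` gives 1000 nM.
Compound 3 `CC(=O)NC(c1ccco1)c1cc(Cl)c2cccnc2c1O` gives 3000 nM.

Compound 2 holds the lowest number of the three in this assay; compound 3 is nearest, at a higher number, and compound 1 is furthest, at the highest number of the set.

Compound 4 `CCC(=O)NC(c1ccco1)c1cc(Br)c2cccnc2c1O` is not yet measured. It differs from compound 2 by bromo in place of chloro on an aromatic carbon.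

For the measured compounds named here, the only one-place step among the measured compounds is a 3.0-fold higher number from compound 2 to compound 3 (0.48 log units; beyond the scatter), which concerns the amide chain and not the halogen, so it does not bear on the change to compound 4. Going by the values given here, compound 1 carries bromo, but it also carries the thiophene in place of the furan, so its difference from compound 2 cannot be split between the two changes; the two values show only that compound 1 sits well above compound 2. Among the compounds with values here, no measured step isolates chloro against bromo on this ring.

With no direct guide, a step of modest size toward a higher number, a 2.5-fold higher number from compound 2 to compound 4 (0.40 log units; beyond the scatter), is expected for compound 4, with wide uncertainty. Compound 4 is estimated at 2500 nM, in the range 700 nM to 10000 nM.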

Compound 4, half-maximal inhibitory concentration: 2000 nM
Estimate against measurement, compound 4: 1.3-fold (0.10 log units) above; low and high end bracket the measured number.
By their numbers in this assay, from the lowest: compounds 2, 4 and 3 (each within the scatter of the next, the first and the last beyond it); then compound 1.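

In this assay, bromo in place of chloro on this aromatic carbon, para to a hydroxy group, gives a 2.0-fold higher number from compound 2 to compound 4 (0.30 log units; within the scatter) and so does not separate the two halogens at this position. For the compounds shown here, compound 4 also supplies the first single-place reading of the other ring on the saturated chain carbon, with furan-2-yl in place of thiophen-2-yl giving a 7.0-fold lower number from compound 1 to compound 4 (0.85 log units; beyond the scatter) while bromo stays on both compounds. Unlike the halogen step, this ring step lies beyond the scatter, but nothing shown offers a reason for either result.

The compounds shown cover only chloro and bromo at this aromatic carbon, so the outcome with hydrogen, a methoxy group or an amine there remains open, as does whether the ring step seen with bromo would carry over to compounds bearing chloro. Also open, from the compounds shown here alone, are a longer chain on the amide carbonyl and a phenyl group in place of furan-2-yl, either of which would show how far these two positions can be changed.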